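Morpholine to Piperidine on a Shared Thiocarbonyl Core

The source may hold more compounds than are shown below. What is called first, only, known or untested is meant among the compounds shown, and "the series" means these compounds.

Compound 1 `N/C(=N\NC(=S)N1CCOCC1)c1ccccn1` gives 81.6% in a functional assay on MCF7 cells (Homo sapiens) for cytotoxicity, read by MTT assay, with a stated time of 72 h, tested at 100 uM; a higher number here means more inhibition of growth at the concentration tested, a lower number less inhibition of growth. Compound 2 `N/C(=N\NC(=S)N1CCCCC1)c1ccccn1` gives 77.7% in this assay. Compound 3 `Cc1cccc(/C(N)=N/NC(=S)N2CCOCC2)n1` gives 74.7% in this assay.

Compound 2 differs from compound 1 by one change, (piperidin-1-yl in place of morpholin-4-yl on a thiocarbonyl carbon), and that change made a step of a number 3.9 percentage points lower from compound 1 to compound 2 (within the scatter). Compound 3 differs from compound 1 by another change, (methyl in place of hydrogen on an aromatic carbon), which made a step of a number 6.9 percentage points lower from compound 1 to compound 3 (within the scatter). Among the measured compounds shown here, for compound 2 and compound 3 no step is computed; their two values lie close to each other.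

Compound 4 `Cc1cccc(/C(N)=N/NC(=S)N2CCCCC2)n1` has not yet been measured in this assay. It differs from compound 3 by piperidin-1-yl in place of morpholin-4-yl on a thiocarbonyl carbon. This is the same change as the one from compound 1 to compound 2, at the same place on the thiocarbonyl carbon, and it occurs twice among these four compounds. Because the earlier step was a number 3.9 percentage points lower from compound 1 to compound 2 (within the scatter) and within the scatter, compound 4 is expected to lie close to compound 3, with an estimated step of a number 3.7 percentage points lower from compound 3 to compound 4 (within the scatter). The estimate for compound 4 in this assay is 71%, expected to fall between 58% and 82%.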

Compound 4, percent growth inhibition at one concentration: 54%
Estimate against measurement, compound 4: 17 percentage points above; measured number below the stated range.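

In this assay, piperidin-1-yl in place of morpholin-4-yl on the thiocarbonyl carbon of the methyl-bearing core gave a step of a number 20.7 percentage points lower from compound 3 to compound 4 (beyond the scatter), and this step did not match the one seen on the other core: the same change on two cores in this assay, a number 3.9 percentage points lower (within the scatter) from compound 1 to compound 2 and a number 20.7 percentage points lower (beyond the scatter) from compound 3 to compound 4, 16.8 percentage points apart, beyond the scatter of two such steps. Read the other way, methyl in place of hydrogen on an aromatic carbon gave a step of a number 23.7 percentage points lower from compound 2 to compound 4 (beyond the scatter), and this change also differed between its two cores: the same change on two cores in this assay, a number 6.9 percentage points lower (within the scatter) from compound 1 to compound 3 and a number 23.7 percentage points lower (beyond the scatter) from compound 2 to compound 4, 16.8 percentage points apart, beyond the scatter of two such steps. The size of either change therefore could not be carried from one core to the other in this series, but four compounds do not show why the steps differ, nor do they give a rule for any further core.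

From the compounds shown here alone, it remains open whether pyrrolidin-1-yl or a dimethylamino group on the thiocarbonyl carbon, or ethyl or chlorine in place of the methyl, would depend on the core in the same way. Readings at a single concentration also leave open how these compounds would compare across a full range of concentrations.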